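A few compounds are considered here, and "the series" means these few. Any claim that something is new, unique, unknown or untested is made for them only; others in the source may bear on it.

Compound 1, `CCOC(=O)CNC(=O)N1CC1C#N`: 25000 nM
Compound 2, `CCOC(=O)c1ccc(NC(=O)N2CC2C#N)cc1`: 3000 nM
Compound 3, `N#CC1CN1C(=O)Nc1cccc2ccccc12`: 8000 nM

Three compounds of the series have been run in a functional assay on RPMI-8226 cells (Homo sapiens) for inhibition; on this read-out higher numbers stand for weaker inhibition and lower numbers for stronger inhibition. Compound 2 gives the lowest number, 3000 nM. Compound 3 comes nearest to it, at 8000 nM, and that gap lies beyond the scatter. Compound 1 stands furthest away, at 25000 nM, also well beyond the scatter. On these numbers compound 2 is the strongest inhibitor of the three, and both compounds that carry an aromatic ring on the urea nitrogen give lower numbers than compound 1 with its ethyl ester chain.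

Compound 4, `N#CC1CN1C(=O)Nc1ccc(S(N)(=O)=O)cc1`, has not yet been measured in this assay. It differs from compound 2 in one place: sulfamoyl in place of ethoxycarbonyl on an aromatic carbon. Going by the values given here, no measured pair shows this exchange, so its effect on the read-out cannot be read from existing steps. The change is expected to leave the number close to that of compound 2, within the scatter or with a small rise. Compound 4 is therefore estimated at 4000 nM, with a range from 1500 nM to 12000 nM. The step expected from compound 2 to compound 4 is a 1.3-fold higher number from compound 2 to compound 4 (0.12 log units; within the scatter).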

Compound 4, half-maximal inhibitory concentration: > 38000 nM
Compound 4 gave a limit, no number; the forecaster's own chance of this, stated with the estimate: 5%; middle value at least 9.5-fold (0.97 log units) from the limit.
By their numbers in this assay, from the lowest: compound 2; then compound 3; then compound 1. At a limit, above all of these: compound 4.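

In this assay, the aromatic carbon that carries ethoxycarbonyl in compound 2 proves sensitive to the group placed there: sulfamoyl in its place gives an at least 12-fold higher number from compound 2 to compound 4 (1.10 log units; beyond the scatter). From the compounds shown here alone, compound 4 gives a limit and not a number, so the true size of this step stays open: the limit of > 38000 nM in this assay, at which 1 of the 4 values shown sits. An aromatic ring on the urea nitrogen, shared by compound 2 and compound 3, does not by itself keep the number low, and compound 4, which carries one too, goes against the earlier pattern.

The compounds shown leave open whether this rise is particular to sulfamoyl or also follows with other groups on this carbon, such as a carboxylic acid or an amine. They also leave open whether a longer ester chain in place of ethoxycarbonyl would move the number of compound 2 in either direction.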